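A few compounds are considered here, and "the series" means these few. Any claim that something is new, unique, unknown or untested is made for them only; others in the source may bear on it.

In a functional assay on HepG2 cells (Homo sapiens) for antiproliferative activity, read by XTT assay, with a stated time of 72 h (on this read-out lower numbers stand for stronger inhibition and higher numbers for weaker inhibition), compound 3 (`COc1nc(N)nc2c1c(-c1ccsc1)cn2[C@@H]1O[C@H](CO)[C@@H](O)[C@H]1O`) gives > 20000 nM and this is a limit, not a number. Compound 2 (`COc1nc(N)nc2c1c(-c1cccs1)cn2[C@@H]1O[C@H](CO)[C@@H](O)[C@H]1O`) gives > 20000 nM and this too is a limit. Compound 1 (`COc1ncnc2c1c(-c1cc3ccccc3o1)cn2[C@@H]1O[C@H](CO)[C@@H](O)[C@H]1O`), which carries 1-benzofuran-2-yl, gives > 20000 nM and this is also a limit. The whole set rests on the limit of > 20000 nM in this assay, at which 3 of the 3 values shown sit, and so compound 3 cannot be ranked against the other two.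

Compound 4 (`COc1nc(N)nc2c1c(-c1cc3ccccc3o1)cn2[C@@H]1O[C@H](CO)[C@@H](O)[C@H]1O`) carries 1-benzofuran-2-yl in place of thiophen-3-yl on an aromatic carbon, a change counted as 1-benzofuran-2-yl in place of thiophen-3-yl on an aromatic carbon on the shared core. Going by the values given here, only one measured step bears on it, a step that the two limits leave unreadable from compound 2 to compound 3 and that step offers no size to carry over. Compound 1 stays at > 20000 nM as a limit, so compound 4 is expected to remain inactive with it, and no step beyond the scatter is expected in this assay in either direction. The expected change is a number no higher from compound 3 to compound 4 (the limit leaves the size open) as an estimate only. For compound 4 the estimated value is 20000 nM with an expected range from 8000 nM to 40000 nM in this read-out.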

Compound 4, half-maximal inhibitory concentration: > 20000 nM
Compound 4: only a limit was reported (the forecaster's own chance of this, stated with the estimate: 85%); the middle value sits exactly at the limit.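

No step can be read between compound 4 and compound 1, compound 2 or compound 3, because each value is a limit and not a number: the limit of > 20000 nM in this assay, at which 4 of the 4 values shown sit.

The compounds shown leave open how these four rank in this assay, and what activity any of them has.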